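The compounds below may be only part of what the source reports. "The series", "measured", "known", "first", "only" and "open" are said of these compounds alone.

Measured so far:
Compound 1 `CCCCCNc1nc(Nc2ccc([N+](=O)[O-])cc2)nc(OCC(F)(F)F)n1`: 35%
Compound 2 `O=C(NS(=O)(=O)CCNC(=O)C1CC1)c1ccc(Nc2nc(NC3(c4ccc(Cl)cc4)CC3)nc(OCC(F)(F)F)n2)cc1`: "not active" (no number reported)
Compound 3 `O=C(NS(=O)(=O)c1ccccc1)c1ccc(Nc2nc(NC3(c4ccc(Cl)cc4)CC3)nc(OCC(F)(F)F)n2)cc1`: 100%

In an ADME assay on microsomes from liver (Rattus norvegicus) for metabolic stability, with a stated time of 10 min (on this read-out higher numbers stand for a more stable compound and lower numbers for a less stable compound), compound 3 stands highest of the two numbers; its nearest neighbour, compound 1, lies lower by a gap beyond the scatter, and compound 2 returned no number. Compound 4 `NCCS(=O)(=O)NC(=O)c1ccc(Nc2nc(NC3(c4ccc(Cl)cc4)CC3)nc(OCC(F)(F)F)n2)cc1` differs from compound 3 in one place: 2-aminoethyl in place of phenyl on a sulfonyl sulfur. Within the data shown here, no measured pair shows this change, so no step size is known for it. Compound 3 already sits at the top of this read-out and can only hold or fall. The step of a number 40 percentage points lower from compound 3 to compound 4 (beyond the scatter) is expected to be a fall beyond the scatter, a step of moderate size. Compound 4 is therefore estimated at 60%. Its expected range runs from 25% to 95%.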

Compound 4, percent of the compound remaining: 100%
Compound 4: middle estimate off by 40 percentage points, on the low side; measured number outside the range, above it.
By their numbers in this assay, from the lowest: compound 1; then compounds 3 and 4 (each within the scatter of the next).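

In this assay, putting 2-aminoethyl in place of phenyl on a sulfonyl sulfur gives no change at the digits printed from compound 3 to compound 4 (within the scatter) and so shows that this position can carry a short open chain ending in an amine, not only an aromatic ring, with no loss on this read-out. Nothing measured here explains that result. As far as these compounds go, whether a carboxylic acid or a longer chain ending in an amine on the same sulfur would hold up as well remains open.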